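Swapping the aryl substituent and expected cytotoxicity in MT4 cells

A few compounds are considered here, and "the series" means these few. Any claim that something is new, unique, unknown or untested is made for them only; others in the source may bear on it.

Measured compounds:
- compound 1, `Cc1cc(C)cc(-c2cc(C)c(Nc3ccnc(Nc4ccc(C#N)cc4)n3)c(C)c2)c1`: 4140 nM
- compound 2, `Cc1cccc(-c2cc(C)c(Nc3ccnc(Nc4ccc(C#N)cc4)n3)c(C)c2)c1`: 3670 nM
- compound 3, `Cc1cc(-c2c(C)cccc2C)cc(C)c1Nc1ccnc(Nc2ccc(C#N)cc2)n1`: 2590 nM

These three share one core and differ only in the aryl group attached to it. In an ADME assay on MT4 cells (Homo sapiens) for cytotoxicity, read by MTT assay, with a stated time of 4 days (on this read-out higher numbers stand for lower toxicity in this test and lower numbers for higher toxicity in this test), compound 1 gives 4140 nM, compound 2 gives 3670 nM and compound 3 gives 2590 nM. Compound 2 stands second highest of the three, and every gap to a neighbour is within the scatter: a 1.1-fold lower number from compound 1 to compound 2 (0.05 log units; within the scatter), a 1.4-fold lower number from compound 2 to compound 3 (0.15 log units; within the scatter) and a 1.6-fold lower number from compound 1 to compound 3 (0.20 log units; within the scatter). So far, changing the methyl pattern on that aryl group has not moved the read-out beyond noise.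

Compound 4, `Cc1cc(-c2ccc(Cl)cc2)cc(C)c1Nc1ccnc(Nc2ccc(C#N)cc2)n1`, has not been measured. It differs from compound 2 by 4-chlorophenyl in place of 3-methylphenyl on an aromatic carbon. No measured step introduces a chlorine, so no step bears on this change directly; the nearest comparisons are the aryl swaps already shown, all within the scatter. On that basis a step of a 1.0-fold lower number from compound 2 to compound 4 (0.02 log units; within the scatter) is expected, that is, none beyond the scatter. Compound 4 is therefore estimated at 3500 nM in this assay, with a range from 1500 nM to 8000 nM.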

Compound 4, half-maximal cytotoxic concentration: 4190 nM
Compound 4: middle estimate off by 1.2-fold (0.08 log units), on the low side, within the range that was stated.
By their numbers in this assay, from the lowest: compounds 3, 2, 1 and 4 (each within the scatter of the next).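

In this assay, the first aryl group carrying chlorine instead of methyl leaves the read-out where the methyl-bearing groups had it: 4-chlorophenyl gives a 1.1-fold higher number from compound 2 to compound 4 (0.06 log units; within the scatter), a 1.6-fold higher number from compound 3 to compound 4 (0.21 log units; within the scatter) and a 1.0-fold higher number from compound 1 to compound 4 (0.01 log units; within the scatter). This position on the shared core therefore accepts a change of substituent element, as well as a change in the methyl pattern, with no step beyond the scatter. No measurement available here explains why the read-out stays so flat.

From the compounds shown here alone, all four groups are phenyl rings carrying only methyl or chlorine, so it remains open whether an amine, a carboxylic acid or a longer chain on that ring would move the number beyond the scatter. The same question stands for a ring containing nitrogen in place of the phenyl ring.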